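A few compounds are considered here, and "the series" means these few. Any claim that something is new, unique, unknown or untested is made for them only; others in the source may bear on it.

Measured so far in a functional assay on DU-145 cells (Homo sapiens) for inhibition, read by sulforhodamine B assay, with a stated time of 48 h; on this read-out lower numbers stand for stronger inhibition and higher numbers for weaker inhibition:
compound 1, `CO[C@@H]1CC=C2NN(c3ccc(C)cc3)C(=O)C[C@]2(C)O1`, 23200 nM;
compound 2, `CO[C@@H]1CC=C2NN(c3ccc(C)cc3)C(=O)C[C@]2(c2ccncc2)O1`, 7100 nM;
compound 3, `CO[C@@H]1CC=C2NN(c3ccc(C)cc3)C(=O)C[C@]2(c2ccccc2)O1`, 11200 nM.

Compound 1 gives the highest of the three numbers in this assay; the nearest step from it is a 2.1-fold lower number from compound 1 to compound 3 (0.32 log units; beyond the scatter) and the furthest a 3.3-fold lower number from compound 1 to compound 2 (0.51 log units; beyond the scatter). The step of a 1.6-fold higher number from compound 2 to compound 3 (0.20 log units; within the scatter) lies within the scatter. All three steps change only the group on the saturated ring carbon.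

Compound 4, `CO[C@@H]1CC=C2NN(c3cccnc3)C(=O)C[C@]2(C)O1`, differs from compound 1 at another place: pyridin-3-yl in place of 4-methylphenyl on an amide-type nitrogen in a ring. Among the measured compounds shown here, no measured step touches the amide-type nitrogen in a ring, so nothing here speaks to the size or direction of this change; the expectation is a step within the scatter, a 1.0-fold lower number from compound 1 to compound 4 (0.00 log units; within the scatter), with a wide range. Compound 4 is therefore estimated at 23000 nM, from 8000 nM to 60000 nM.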

Compound 4, half-maximal inhibitory concentration: 16400 nM
Estimate against measurement, compound 4: 1.4-fold (0.15 log units) above; the range from low to high includes it.
By their numbers in this assay, from the lowest: compounds 2, 3, 4 and 1 (each within the scatter of the next, the first and the last beyond it).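

Pyridin-3-yl in place of 4-methylphenyl on the amide-type nitrogen in a ring gives a 1.4-fold lower number from compound 1 to compound 4 (0.15 log units; within the scatter) in this assay. Among the compounds shown here, this is the first reading at this position, and with methyl on the saturated ring carbon, the exchange of a carbon-only aromatic ring for one with a ring nitrogen leaves the number within the scatter. No evidence on the reason for this result is available here.

For the compounds shown here, it remains open whether pyridin-3-yl combined with phenyl or pyridin-4-yl on the saturated ring carbon behaves as the single changes do. As far as these compounds go, it is also open what a benzyl group or an ethyl chain on that nitrogen would give.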